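The source may hold more compounds than are shown below. What is called first, only, known or untested is meant among the compounds shown, and "the series" means these compounds.

Compound 1 `Cc1cc(OCc2ccccn2)c2cccc(O)c2n1` is a small fused-ring compound that, in a functional assay on MDA-MB-231 cells (Homo sapiens) for antiproliferative activity, with a stated time of 24 h (on this read-out higher numbers stand for weaker inhibition and lower numbers for stronger inhibition), gives 450000 nM, the highest of the three numbers shown and therefore the weakest inhibition among them. Compound 3 `Cc1cc(OCc2ccccn2)c2cccc(OCc3cccc(Oc4ccccc4)c3)c2n1` gives 6970 nM, and compound 2 `COc1cc(/C=C/C(=O)NCC(=O)N(C)c2ccc(Cl)c(COc3cccc4c(OCc5ccccn5)cc(C)nc34)c2Cl)ccc1O` gives 5900 nM; both stand far below compound 1, beyond the usual scatter. Compound 4 `Cc1cc(OCc2ccccn2)c2cccc(N)c2n1` keeps the core of compound 1 and differs from it only by amino in place of hydroxy on an aromatic carbon. Within the data shown here, no measured pair shows this particular swap, so nothing here tells directly how it plays out. Because compound 1 sits at 450000 nM, a step of a 1.1-fold lower number from compound 1 to compound 4 (0.05 log units; within the scatter) is expected, that is no change beyond the scatter. Compound 4 is therefore estimated at 400000 nM, in a range from 150000 nM to 1000000 nM.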

Compound 4, half-maximal inhibitory concentration: 22000 nM
The estimate for compound 4 lay 18-fold (1.26 log units) above the measured number, outside the stated range (below it).
By their numbers in this assay, from the lowest: compounds 2 and 3 (each within the scatter of the next); then compound 4; then compound 1.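

On this aromatic carbon, a change of one heavy atom is enough to move the result: in this assay, amino in place of hydroxy gives a 20-fold lower number from compound 1 to compound 4 (1.31 log units; beyond the scatter). The counts of hydrogen-bond donors and acceptors and the net charge stay the same across this swap, yet the number still shifts beyond the scatter. Nothing available explains the step. Still open, as far as these compounds go, is how a methoxy group, a methylamino group or a fluorine on this same carbon would read in this assay.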